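The compounds below may be only part of what the source reports. "The series", "measured", "known", "first", "only" and "open" are said of these compounds alone.

Working notes on the series. Of the compounds shown here, three sharing the same core have been measured in a functional assay on isolated protein for inhibition of Glucose-dependent insulinotropic receptor (Homo sapiens), read by HTRF and cAMP accumulation; a higher number here means that more compound is needed for the effect, a lower number that less compound is needed. Compound 3 `Cc1nc(S(C)(=O)=O)ccc1Oc1ncnc(OC2CCN(C(=O)C3(F)CCC3)CC2)c1F` gives 24.7 nM and stands with the highest of the three numbers. Its nearest neighbour is compound 1 `Cc1nc(S(C)(=O)=O)ccc1Oc1ncnc(OC2CCN(C(=O)OC(C)C)CC2)c1F`, which gives 21 nM; the step is a 1.2-fold higher number from compound 1 to compound 3 (0.07 log units; within the scatter). The furthest is compound 2 `Cc1nc(S(C)(=O)=O)ccc1Oc1ncnc(OC2CCN(C(=O)SC(C)C)CC2)c1F`, which gives 6.8 nM; here the step is a 3.6-fold higher number from compound 2 to compound 3 (0.56 log units; beyond the scatter). The remaining measured step, a 3.1-fold lower number from compound 1 to compound 2 (0.49 log units; beyond the scatter), lies between the other two compounds.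

The next compound, compound 4 `Cc1nc(S(C)(=O)=O)ccc1Oc1ncnc(OC2CCN(C(=O)c3noc(C(C)(C)F)n3)CC2)c1F`, differs from compound 3 only at the carbonyl carbon: a group of 9 heavy atoms (5 carbon, 2 nitrogen, 1 oxygen, 1 fluorine; one five-membered aromatic ring with 3 hetero atoms) in place of a group of 5 heavy atoms (4 carbon, 1 fluorine; one four-membered non-aromatic ring of carbon only), on a carbonyl carbon. All three measured steps vary the group on this same carbonyl carbon, so all of them bear on the change, but none of them brings in an aromatic ring, and the largest move seen among them is the modest one from compound 2 to compound 3. The replacement of the four-membered non-aromatic ring by the five-membered aromatic ring with 3 hetero atoms is therefore expected to give at most a modest step in this assay, with no direction clearly favoured by the data.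

On that basis compound 4 is expected at 25 nM, within a range of 8 nM to 80 nM, which means an expected step of a 1.0-fold higher number from compound 3 to compound 4 (0.01 log units; within the scatter).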

Compound 4, half-maximal effective concentration: 14 nM
Beside the measured number, compound 4's estimate is 1.8-fold (0.25 log units) above it, and the stated range covers the measured number.
By their numbers in this assay, from the lowest: compound 2; then compounds 4, 1 and 3 (each within the scatter of the next).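

In this assay, the five-membered aromatic ring with 3 hetero atoms is carried on the carbonyl carbon without a step beyond the scatter from either of two neighbours: a 1.8-fold lower number from compound 3 to compound 4 (0.25 log units; within the scatter), and a 1.5-fold lower number from compound 1 to compound 4 (0.18 log units; within the scatter). This holds although the entering group has 9 heavy atoms and 3 hydrogen-bond acceptors, whereas the group leaving compound 3 has 5 heavy atoms and no hydrogen-bond acceptors, so neither count tracks a large shift across this small set. Within the data shown here, the isopropylsulfanyl group of compound 2 still stands apart, with a 2.1-fold higher number from compound 2 to compound 4 (0.31 log units; beyond the scatter), a modest step; no measurement accompanying these compounds speaks to the origin of any of these differences.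

The compounds shown leave open whether the aromatic ring itself or its fluorine-bearing side group sets the number for compound 4, a question that the same ring bearing a plain methyl group would address. They also leave open how a dimethylamino group on the same carbonyl carbon would compare with the isopropylsulfanyl group of compound 2.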